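From an Acid to a Methyl Amide on a Shared Core

The compounds below may be only part of what the source reports. "The series", "measured", "known", "first", "only" and "open" are said of these compounds alone.

Compound 1 `O=[N+]([O-])c1cccc(CNc2cc(C(F)(F)F)cc3[nH]ncc23)c1` carries a nitro group on an aromatic carbon. In an assay for inhibition of Indoleamine 2,3-dioxygenase 1 (Homo sapiens), with stated times of 10 min and 60 min (on this read-out higher numbers stand for weaker inhibition and lower numbers for stronger inhibition), compound 1 gives > 100000 nM, which is a limit of the assay rather than a number. Compound 2 `O=C(O)c1cccc(CNc2cc(C(F)(F)F)cc3[nH]ncc23)c1` has a carboxy in place of that nitro on the same aromatic carbon. In this assay compound 2 gives > 100000 nM, again a limit and not a number. The step that the two limits leave unreadable from compound 1 to compound 2 can therefore not be read in size or direction. Compound 2 stands at the limit (the limit of > 100000 nM in this assay, at which 2 of the 2 values shown sit), so no number places it against anything.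

Compound 3 `CNC(=O)c1cccc(CNc2cc(C(F)(F)F)cc3[nH]ncc23)c1` differs from compound 2 by methylamino in place of hydroxy on a carbonyl carbon. Going by the values given here, the only measured step, from compound 1 to compound 2, is unreadable, so nothing measured in this set gives a gauge for the change from carboxy to methylcarbamoyl. Compound 2 sits at the limit (the limit of > 100000 nM in this assay, at which 2 of the 2 values shown sit), which gives no number from which a change could be measured. The step of a number no higher from compound 2 to compound 3 (the limit leaves the size open) is therefore expected to show nothing readable. Compound 3 is expected to give 100000 nM in this assay, with a range from 30000 nM to 300000 nM, most likely again reported as a limit.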

Compound 3, half-maximal inhibitory concentration: > 100000 nM
Compound 3: only a limit was reported (the forecaster's own chance of this, stated with the estimate: 75%); the middle value sits exactly at the limit.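

In this assay compound 3 gives > 100000 nM as a limit of the assay and not a number. Going by these compounds alone, no step among compound 1, compound 2 and compound 3 can be read in size or direction. The compounds shown leave open how strongly each inhibits the enzyme, and whether nitro, carboxy and methylcarbamoyl differ at all in this respect.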